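Swapping Methyl for Methoxy on the Far Phenyl Ring

A few compounds are considered here, and "the series" means these few. Any claim that something is new, unique, unknown or untested is made for them only; others in the source may bear on it.

Of the compounds shown here, two sharing one core have been tested in a functional assay on MDA-MB-231 cells (Homo sapiens) for cytotoxicity, read by MTT assay, with a stated time of 72 h; on this read-out lower numbers stand for stronger inhibition and higher numbers for weaker inhibition. Compound 1 `Cc1ccc(-c2ccc(C)n2-c2ccc(-c3nc4ccc(F)cc4s3)cc2)cc1` gives 16700 nM. Where compound 1 carries a fluoro, a methoxy sits in compound 2 `COc1ccc2nc(-c3ccc(-n4c(C)ccc4-c4ccc(C)cc4)cc3)sc2c1`, and compound 2 gives 20500 nM. That change amounts to a 1.2-fold higher number from compound 1 to compound 2 (0.09 log units; within the scatter), so the two numbers cannot be told apart. Compound 2 thus has the higher of the two numbers, but only by a margin that means nothing on its own.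

Compound 3 `COc1ccc(-c2ccc(C)n2-c2ccc(-c3nc4ccc(OC)cc4s3)cc2)cc1` is not yet measured. It differs from compound 2 by methoxy in place of methyl on an aromatic carbon; cut one bond further out, the change reads 4-methylphenyl to 4-methoxyphenyl. Among the compounds with values here, no measured pair shows this exact swap. Within the data shown here, the only measured step, from compound 1 to compound 2, brought a methoxy in at a different place and stayed within the scatter, and that is the one clue available. On that basis the step from compound 2 to compound 3 is expected to be a 1.1-fold higher number from compound 2 to compound 3 (0.03 log units; within the scatter), a change not beyond the scatter. Compound 3 is therefore estimated at 22000 nM in this assay, with a likely range from 9000 nM to 55000 nM.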

Compound 3, half-maximal inhibitory concentration: 12700 nM
Beside the measured number, compound 3's estimate is 1.7-fold (0.24 log units) above it; the range from low to high includes it.
By their numbers in this assay, from the lowest: compounds 3, 1 and 2 (each within the scatter of the next).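

Placing 4-methoxyphenyl where compound 2 has 4-methylphenyl gives, in this assay, a 1.6-fold lower number from compound 2 to compound 3 (0.21 log units; within the scatter) and stays within the scatter, so this is the first look at the group para to a large group, and the methoxy there, with its hydrogen-bond acceptor, cannot be told apart from the methyl. The earlier step, a 1.2-fold higher number from compound 1 to compound 2 (0.09 log units; within the scatter), was also within the scatter, so neither of the two single changes measured so far has shifted the number by more than repeated measurement could. The data hold nothing that would explain the size of this step.

At this position the compounds shown carry only methyl and methoxy, which are small groups, so it remains open whether an amine, a carboxylic acid or a longer chain in that place would move the number beyond the scatter. On these data alone, it is also open whether the swap from 4-methylphenyl to 4-methoxyphenyl would behave the same way on a core carrying fluoro instead of methoxy, as compound 1 does.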